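The source may hold more compounds than are shown below. What is called first, only, known or untested is meant among the compounds shown, and "the series" means these compounds.

Working notes on the series.

Compound 1 `CC(C)(C)N(NC(=O)c1ccccc1)C(=O)c1ccccc1Cl` gives 75.9 nM in an assay on cells for agonist activity at ecdysone receptor (Bombyx mori), read by a luciferase reporter, with a stated time of 24 h; a lower number here means that less compound is needed, a higher number that more compound is needed for the effect. Compound 2 `CC(C)(C)N(NC(=O)c1cccc(Cl)c1)C(=O)c1ccccc1Cl` gives 155 nM; the step of a 2.0-fold lower number from compound 2 to compound 1 (0.31 log units; beyond the scatter) is the change (hydrogen in place of chloro on an aromatic carbon). Compound 3 `CCc1ccc(C(=O)NN(C(=O)c2ccccc2Cl)C(C)(C)C)cc1` gives 5.75 nM, the lowest number of the three, and stands apart from compound 1 by a 13-fold lower number from compound 1 to compound 3 (1.12 log units; beyond the scatter) and from compound 2 by a 27-fold lower number from compound 2 to compound 3 (1.43 log units; beyond the scatter). The cores of compound 2 and compound 3 differ by 4-ethylphenyl in place of 3-chlorophenyl on a carbonyl carbon.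

Compound 4 `CCc1ccc(C(=O)NN(C(=O)c2ccccc2)C(C)(C)C)cc1` is not yet measured. It differs from compound 3 by hydrogen in place of chloro on an aromatic carbon. This is the same kind of change as that from compound 2 to compound 1, seen twice in the set, but not the same: there the chloro left a position meta to a large group, here it leaves a position ortho to a large group, on the other aromatic ring. The earlier step was modest, so a step of similar size is expected here, giving a 1.4-fold lower number from compound 3 to compound 4 (0.16 log units; within the scatter), resting on the step of a 2.0-fold lower number from compound 2 to compound 1 (0.31 log units; beyond the scatter) and on the value of compound 3 5.75 nM. Compound 4 is therefore estimated at 4 nM, with a likely range of 1.5 nM to 15 nM in this assay.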

Compound 4, half-maximal effective concentration: 4.9 nM
Compound 4: middle estimate off by 1.2-fold (0.09 log units), on the low side, within the range that was stated.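

In this assay, hydrogen in place of chloro on an aromatic carbon gives a 1.2-fold lower number from compound 3 to compound 4 (0.07 log units; within the scatter), and the two occurrences of this change can be set side by side: the same change on two cores in this assay, a 2.0-fold lower number (0.31 log units; beyond the scatter) from compound 2 to compound 1 and a 1.2-fold lower number (0.07 log units; within the scatter) from compound 3 to compound 4, 1.7-fold (0.24 log units) apart, within the scatter of two such steps. The change therefore carries between these two cores with no detectable difference in the size of the step, although one step lies beyond the scatter and the other within it. Within the data shown here, this does not show that the step would hold on any other core, or that the place of the chloro makes no difference: there is only one pair of steps, and the chloro leaves a 3-chlorophenyl group in one and a 2-chlorophenyl group in the other.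

The compounds shown leave open how a methyl, a methoxy or an amine would read in the place ortho to a large group. They also leave open whether a longer chain in place of the ethyl of compound 3 and compound 4 would keep the numbers as low.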